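Removing the nitro group: compound 2 to compound 3

The source may hold more compounds than are shown below. What is called first, only, known or untested is meant among the compounds shown, and "the series" means these compounds.

Measured so far:
Compound 1, `COc1ccccc1/C=N/c1c(C)n(C)n(-c2ccccc2)c1=O`, gives 933000000 nM in a functional assay on DLD-1 cells (Homo sapiens) for cytotoxicity, read by MTT assay, with a stated time of 72 h; a higher number here means a weaker inhibitor, a lower number a stronger inhibitor.
Compound 2, `Cc1c(/N=C/c2cccc([N+](=O)[O-])c2)c(=O)n(-c2ccccc2)n1C`, gives 490000000 nM in this assay.

Compound 2 has the lowest of the two numbers, but compound 1 sits only a little higher, and that gap lies within the scatter of repeated measurements, so the two cannot be told apart on these data. Both numbers are very high, which marks both compounds as weak in this assay.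

Compound 3, `Cc1c(/N=C/c2ccccc2)c(=O)n(-c2ccccc2)n1C`, is the next compound. It differs from compound 2 in one place: hydrogen in place of nitro on an aromatic carbon.

For the measured compounds named here, with no comparable step among the measured compounds to lean on, and both measured values already far up the scale, no change beyond the scatter is expected in this assay for this change. Compound 3 is therefore estimated at 700000000 nM, with a range from 200000000 nM to 3000000000 nM. The step this estimate means is a 1.4-fold higher number from compound 2 to compound 3 (0.15 log units; within the scatter), expected to stay within the usual scatter.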

Compound 3, half-maximal inhibitory concentration: 933000000 nM
Estimate against measurement, compound 3: 1.3-fold (0.12 log units) below; measured number inside the range.
By their numbers in this assay, from the lowest: compounds 2, 1 and 3 (each within the scatter of the next).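

In this assay, hydrogen in place of nitro on an aromatic carbon gives a 1.9-fold higher number from compound 2 to compound 3 (0.28 log units; within the scatter) and so cannot be told apart from no effect at this ring position. Hydrogen in place of methoxy on an aromatic carbon gives no change at the digits printed from compound 1 to compound 3 (within the scatter) and likewise shows no measurable difference, so on these numbers neither nitro nor methoxy can be distinguished from a bare ring, and all three compounds remain very weak. No measured evidence bears on why these numbers fall as they do.

On these data alone, whether an amine or a carboxylic acid on this ring would shift the number beyond the scatter remains open. So does whether a change elsewhere on the shared core would do so.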